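From sec-butyl to phenyl on the shared core

This account rests on a few compounds, and the source may have more. Where it says the series, first, only, none or still open, it means among the compounds named here.

In a functional assay (Nicotiana tabacum) (on this read-out higher numbers stand for weaker inhibition and lower numbers for stronger inhibition), compound 1 `CSc1nc(NCC(C)C)c2cccnc2n1` reads 540 nM and compound 2 `CCC(C)Nc1nc(SC)nc2ncccc12` reads 860 nM with nothing to separate the two. Within the data shown here, the one measured step shows a 1.6-fold higher number from compound 1 to compound 2 (0.20 log units; within the scatter) and exchanges one alkyl group for another, so it guides the next move only loosely. Compound 3 `CSc1nc(Nc2ccccc2)c2cccnc2n1` has phenyl in place of sec-butyl on a nitrogen on an aromatic ring, and phenyl in place of sec-butyl on a nitrogen on an aromatic ring sets out that difference. The expected change is modest, toward a higher number, and is estimated as a 1.7-fold higher number from compound 2 to compound 3 (0.24 log units; within the scatter) in this assay with wide uncertainty. Compound 3 is estimated at 1500 nM with 300 nM to 8000 nM as its expected range.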

Compound 3, half-maximal inhibitory concentration: 15900 nM
Compound 3: the middle estimate sits 11-fold (1.03 log units) below what was measured, and the stated range ends below it.
By their numbers in this assay, from the lowest: compounds 1 and 2 (each within the scatter of the next); then compound 3.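

On a nitrogen on an aromatic ring, the swap of one alkyl group for another had stayed within the scatter, but this position proves far from indifferent once phenyl enters. In this assay the change to phenyl gives an 18-fold higher number from compound 2 to compound 3 (1.27 log units; beyond the scatter) and, set against isobutyl, a 29-fold higher number from compound 1 to compound 3 (1.47 log units; beyond the scatter), so inhibition is clearly weaker with phenyl than with either alkyl group. No available evidence accounts for this loss. On these data alone, whether cyclohexyl or benzyl on that nitrogen would read nearer the alkyl compounds or nearer compound 3 stays open, as does the effect of a methoxy group on the phenyl ring.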